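The compounds below may be only part of what the source reports. "The series", "measured", "known", "first", "only" and "open" are said of these compounds alone.

Compound 1 `CNc1nc(NCc2ccccc2)nc(-c2ccccc2CO)n1` gives 4.51; compound 2 `CCNc1nc(NCc2ccccc2)nc(-c2ccccc2CO)n1` gives 4.63; compound 3 `COc1ccc(CNc2nc(N)nc(-c3ccccc3CO)n2)cc1` gives 3.34.

These three compounds were measured in a functional assay on cells for positive allosteric modulation of G-protein coupled receptor 68 (Homo sapiens), read by a luciferase reporter and cAMP accumulation, with a stated time of 30 min, at pH 6.8 and pH 8.3, in the presence of a further agent that is not named here; on this read-out higher numbers stand for higher potency (the scale is a negative logarithm) and lower numbers for lower potency. Compound 2 differs from compound 1 by methyl in place of hydrogen on a saturated chain carbon bound to a nitrogen on an aromatic ring, and this step is a number 0.12 log units higher from compound 1 to compound 2 (within the scatter). Compound 3 stands apart from compound 1 on a different core; the difference between the two cores is not broken down here. Compound 4 `CCOc1ccc(CNc2nc(N)nc(-c3ccccc3CO)n2)cc1` has not yet been measured, and differs from compound 3 by methyl in place of hydrogen on a saturated chain carbon bound to an oxygen on an aromatic ring. This is the same kind of change as that from compound 1 to compound 2, though here the carbon is bound to an oxygen on an aromatic ring rather than to a nitrogen on an aromatic ring. Because the earlier step was a number 0.12 log units higher from compound 1 to compound 2 (within the scatter), a similarly small step is expected, a number 0.11 log units higher from compound 3 to compound 4 (within the scatter). Compound 4 is thus estimated to give 3.45 in this assay, between 2.95 and 3.95.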

Compound 4, negative logarithm of the antagonist equilibrium constant: 4.77
The estimate for compound 4 lay 1.32 log units below the measured number, outside the stated range (above it).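

The move from methoxy to ethoxy gives a number 1.43 log units higher from compound 3 to compound 4 (beyond the scatter) in this assay, and the size of this step did not carry over from the other core: the same change on two cores in this assay, a number 0.12 log units higher (within the scatter) from compound 1 to compound 2 and a number 1.43 log units higher (beyond the scatter) from compound 3 to compound 4, 1.31 log units apart, beyond the scatter of two such steps. A small step on one core therefore did not predict the step on the other, although the change is the same kind in both. This does not show why the steps differ: each rests on a single pair of compounds, and the carbon is bound to a nitrogen in one pair and to an oxygen in the other, so the core and the place of the change cannot be told apart.

As far as these compounds go, it remains open whether a longer chain, such as propoxy, would extend the step from methoxy to ethoxy. Also open, from the compounds shown here alone, is how an amine at the end of that chain would read out.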